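This account rests on a few compounds, and the source may have more. Where it says the series, first, only, none or still open, it means among the compounds named here.

Measured compounds:
compound 2 `C[C@H](Nc1ncnc2[nH]cnc12)c1nn(-c2cccc(F)c2)c2cc(F)ccc12` — 33%
compound 1 `C[C@H](Nc1nc(N)nc(N)c1C#N)c1nn(-c2cccc(S(C)(=O)=O)c2)c2cc(F)ccc12` — 24%

In a functional assay on HepG2 cells (Homo sapiens) for inhibition, read by sulforhodamine B assay, with a stated time of 72 h, tested at 10 uM (a lower number here means less inhibition, a higher number more inhibition at the concentration tested (going by the name of the read-out)), compound 2 gives 33%, the higher of the two numbers in hand, while compound 1 gives 24%; the gap between compound 2 and compound 1 lies within the scatter, so the two readings cannot be told apart. Compound 3 `C[C@H](Nc1ncnc2[nH]cnc12)c1nn(-c2ccccn2)c2cc(F)ccc12` has not yet been measured. It differs from compound 2 in one place: pyridin-2-yl in place of 3-fluorophenyl on an aromatic nitrogen. The shared core and the side chain otherwise stay as in compound 2. Within the data shown here, no step between measured compounds is available to show how this assay answers a change on the aromatic nitrogen, so the expectation rests on compound 2 alone, whose value 33% is low. The step expected here, a number 5 percentage points lower from compound 2 to compound 3 (within the scatter), is estimated to stay within the scatter. Compound 3 is accordingly expected to give about 28%, within 10% to 48%.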

Compound 3, a percentage reported as inhibition, at one concentration (the size of the read-out at that concentration, not a potency): 22%
Beside the measured number, compound 3's estimate is 6 percentage points above it, within the range that was stated.
By their numbers in this assay, from the lowest: compounds 3, 1 and 2 (each within the scatter of the next, the first and the last beyond it).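

In this assay, the aromatic nitrogen of the five-membered ring gets its first readable step: pyridin-2-yl in place of 3-fluorophenyl gives a number 11 percentage points lower from compound 2 to compound 3 (beyond the scatter) and shows that the reading at this position responds to an exchange of one six-membered aromatic ring for another. The entering ring brings a ring nitrogen and a hydrogen-bond acceptor, and the leaving ring takes away a fluorine, so this single step cannot separate those differences. Nothing available explains the direction of this step.

On these data alone, whether a pyridin-3-yl ring or a plain methyl group on this aromatic nitrogen would read differently remains open. Also open, as far as these compounds go, is whether the step would hold on the core of compound 1, which differs from compound 2 in more than one place.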